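Capping a carboxy group on compound 3

This account rests on a few compounds, and the source may have more. Where it says the series, first, only, none or still open, it means among the compounds named here.

In a functional assay on HeLa cells (Homo sapiens) for inhibition, read by MTT assay, with a stated time of 72 h (on this read-out lower numbers stand for stronger inhibition and higher numbers for weaker inhibition), compound 1 `CC(=O)Oc1cc(C(=O)C2=C(O)[C@]3(CC=C(C)C)C[C@@H](C/C=C(\C)CCC=C(C)C)[C@](C)(CCC=C(C)C)[C@](CC=C(C)C)(C2=O)C3=O)ccc1O` gives 8970 nM, and compound 2 `CC(=O)Oc1ccc(C(=O)C2=C(O)[C@]3(CC=C(C)C)C[C@@H](C/C=C(\C)CCC=C(C)C)[C@](C)(CCC=C(C)C)[C@](CC=C(C)C)(C2=O)C3=O)cc1OC(C)=O` gives 13400 nM. Compound 3 `CC(C)=CCC/C(C)=C/C[C@@H]1C[C@]2(CC=C(C)C)C(=O)[C@@](CC=C(C)C)(C(=O)C(C(=O)c3ccc(OCC(=O)O)c(OCC(=O)O)c3)=C2O)[C@@]1(C)CCC=C(C)C` returns no number, only the assay limit > 20000 nM. Compound 4 `COC(=O)COc1ccc(C(=O)C2=C(O)[C@]3(CC=C(C)C)C[C@@H](C/C=C(\C)CCC=C(C)C)[C@](C)(CCC=C(C)C)[C@](CC=C(C)C)(C2=O)C3=O)cc1OCC(=O)O` differs from compound 3 by methyl in place of hydrogen on an oxygen next to a carbonyl group, which turns carboxymethyl to (methoxycarbonyl)methyl. Among the compounds with values here, the only measured step is a 1.5-fold higher number from compound 1 to compound 2 (0.17 log units; within the scatter), for acetyl in place of hydrogen on an oxygen on an aromatic ring, a related but different change. Within the data shown here, with that step as the sole guide, no shift beyond the scatter is expected in this assay. The expected change is an at least 1.1-fold lower number from compound 3 to compound 4 (0.07 log units; that floor lies within the scatter). The estimate for compound 4 is 17000 nM, with an expected range from 8000 nM to 32000 nM.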

Compound 4, half-maximal inhibitory concentration: > 20000 nM
Compound 4 was reported as a limit; the forecaster's own chance of this, stated with the estimate: 55%; middle value at least 1.1-fold (0.07 log units) from the limit.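

Compound 3 and compound 4 are both reported only as limits in this assay, so no step between them can be read: the limit of > 20000 nM in this assay, at which 2 of the 4 values shown sit.

The compounds shown leave open whether (methoxycarbonyl)methyl in place of carboxymethyl changes the number at all.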